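Swapping the aryl group on an isoxazole-linked core

A few compounds are considered here, and "the series" means these few. Any claim that something is new, unique, unknown or untested is made for them only; others in the source may bear on it.

Among the compounds with values here, compound 1 `COc1ccc(-c2cc(CO[C@H]3CC(=O)[C@@H]4OC[C@H]3O4)on2)cc1` was tested in a functional assay on MDA-MB-231 cells (Homo sapiens) for cytotoxicity, read by MTT assay, with a stated time of 48 h (a higher number here means a weaker inhibitor, a lower number a stronger inhibitor), where compound 1 gives 21900 nM, the highest of the two numbers so far. Its nearest neighbour, compound 2 `O=C1C[C@H](OCc2cc(-c3ccc([N+](=O)[O-])cc3)no2)[C@H]2CO[C@@H]1O2`, gives 16500 nM in this assay, and the step of a 1.3-fold lower number from compound 1 to compound 2 (0.12 log units; within the scatter) comes from a nitro in place of methoxy on an aromatic carbon. Compound 3 `O=C1C[C@H](OCc2cc(-c3ccc(Cl)o3)no2)[C@H]2CO[C@@H]1O2` has not yet been measured; it differs from compound 1 by 5-chlorofuran-2-yl in place of 4-methoxyphenyl on an aromatic carbon, on an aromatic carbon of the five-membered aromatic ring with one nitrogen and one oxygen, next to the ring nitrogen. Within the data shown here, the only measured step, which changes a group on the same aryl arm, stayed within the scatter, so no step beyond the scatter is expected here either, in either direction. Compound 3 is therefore estimated at 20000 nM, with a range from 6000 nM to 65000 nM, an expected step of a 1.1-fold lower number from compound 1 to compound 3 (0.04 log units; within the scatter).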

Compound 3, half-maximal inhibitory concentration: 13800 nM
The estimate for compound 3 lay 1.4-fold (0.16 log units) above the measured number; measured number inside the range.
By their numbers in this assay, from the lowest: compounds 3, 2 and 1 (each within the scatter of the next).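

Compound 3 shows that at this position, on an aromatic carbon of the five-membered aromatic ring and next to the ring nitrogen, the whole ring can be exchanged, not only a group on it. Putting 5-chlorofuran-2-yl in place of 4-methoxyphenyl gives a 1.6-fold lower number from compound 1 to compound 3 (0.20 log units; within the scatter) in this assay, so a smaller ring carrying a chlorine leaves the number within the usual scatter. Nothing measured here bears on why the number holds so steady under this change.

With no step beyond the scatter, the compounds shown do not yet reveal any change at this position that truly moves cytotoxicity. They leave open whether an amine, a carboxylic acid or an open butyl chain in place of the aromatic ring would shift the number.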